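The source may report more compounds than this note shows. Statements on the series, on what has been measured and on what is new or still open speak of the compounds shown alone.

Working notes on the series. Of the compounds shown here, two have been measured in an assay on membranes from liver (strain Sprague-Dawley) for displacement of a labelled ligand from Sigma intracellular receptor 2 (Rattus norvegicus), read by scintillation counting, with a stated time of 90 min, in the presence of a further agent that is not named here; on this read-out lower numbers stand for stronger inhibition and higher numbers for weaker inhibition. Compound 1, `O[C@H]1CCCC[C@@H]1N1CCN(CCCc2ccc(Br)cc2)CC1`, gives 26 nM. Compound 2, `O[C@H]1CCC[C@@H]1N1CCN(CCCc2cccc(Br)c2)CC1`, gives 8.1 nM. Among the compounds with values here, compound 2 thus stands at the lowest of the two numbers, and its gap to compound 1, the only other measured compound, lies beyond the scatter. Within the data shown here, compounds 1 and 2 differ in more than one place, so their two values show only that the pair is separated, not what any single change does.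

Compound 3, `O[C@H]1CCC[C@@H]1N1CCN(CCCc2ccc(Br)cc2)CC1`, is not yet measured. It differs from compound 2 by 4-bromophenyl in place of 3-bromophenyl on a saturated chain carbon, three bonds along the chain from an amine nitrogen in a ring. Among the measured compounds shown here, no pair of measured compounds shows this change on its own. Compound 1 carries the same 4-bromophenyl but also a different ring on the hydroxyl side, so its value of 26 nM does not isolate the change. The expectation is a step in this assay from compound 2 to compound 3 that is small and toward a higher number, of the order a 1.9-fold higher number from compound 2 to compound 3 (0.27 log units; within the scatter), since nothing measured supports a large move. Compound 3 is estimated at 15 nM in this assay, with a range from 5 nM to 45 nM.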

Compound 3, inhibition constant: 12.6 nM
Beside the measured number, compound 3's estimate is 1.2-fold (0.08 log units) above it; the measured number falls inside the stated range.
By their numbers in this assay, from the lowest: compounds 2 and 3 (each within the scatter of the next); then compound 1.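

In this assay, 4-bromophenyl in place of 3-bromophenyl on a saturated chain carbon, three bonds along the chain from an amine nitrogen in a ring, gives a 1.6-fold higher number from compound 2 to compound 3 (0.19 log units; within the scatter), so with the 2-hydroxycyclopentyl group held constant, this read-out does not separate the two bromophenyl groups at this position. Compound 3 also gives the series its first single-change step on the other side of the molecule: 2-hydroxycyclopentyl in place of 2-hydroxycyclohexyl on an amine nitrogen in a ring gives a 2.1-fold lower number from compound 1 to compound 3 (0.31 log units; beyond the scatter), a modest step that only just clears the scatter. No supporting data bear on either step.

It remains open whether the exchange of 4-bromophenyl for 3-bromophenyl would read the same with 2-hydroxycyclohexyl on the amine nitrogen in a ring, since the compounds shown test it only with 2-hydroxycyclopentyl. Also open, on these data alone, is how the number would respond to an unsubstituted phenyl, a chlorophenyl or a methoxyphenyl in place of the bromophenyl, or to a longer chain between that ring and the amine nitrogen.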